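The source may hold more compounds than are shown below. What is called first, only, known or untested is meant among the compounds shown, and "the series" means these compounds.

In a functional assay on A549 cells (Homo sapiens) for cytotoxicity, read by MTT assay, with a stated time of 72 h (a higher number here means a weaker inhibitor, a lower number a stronger inhibitor), compound 1 `N#Cc1ccc(/C=N/NC(=O)Nc2cc3c(Nc4ccc(F)c(Cl)c4)ncnc3cc2O[C@H]2CCOC2)cc1` gives 29100 nM, compound 2 `COc1cc(/C=N/NC(=O)Nc2cc3c(Nc4ccc(F)c(Cl)c4)ncnc3cc2O[C@H]2CCOC2)cc(OC)c1OC` gives 26400 nM and compound 3 `CCN(CC)c1ccc(/C=N/NC(=O)Nc2cc3c(Nc4ccc(F)c(Cl)c4)ncnc3cc2O[C@H]2CCOC2)c(O)c1` gives 15700 nM, so compound 1 stands level with both, within the scatter. Compound 4 `COc1cc2ncnc(Nc3ccc(F)c(Cl)c3)c2cc1NC(=O)N/N=C/c1ccc(C#N)cc1` differs from compound 1 on an oxygen on an aromatic ring, with methyl in place of oxolan-3-yl on an oxygen on an aromatic ring. The measured steps, a 1.1-fold lower number from compound 1 to compound 2 (0.04 log units; within the scatter), a 1.9-fold lower number from compound 1 to compound 3 (0.27 log units; within the scatter) and a 1.7-fold lower number from compound 2 to compound 3 (0.23 log units; within the scatter), all lie within the scatter, but each changes the group on a carbon with a double bond to nitrogen. None tests this oxygen, so they bear only indirectly and give no direction. In this assay, no step beyond the scatter is expected. The expected change is a 1.3-fold lower number from compound 1 to compound 4 (0.12 log units; within the scatter). Compound 4 is estimated at 22000 nM, with an expected range of 8000 nM to 50000 nM.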

Compound 4, half-maximal inhibitory concentration: 32200 nM
The estimate for compound 4 lay 1.5-fold (0.17 log units) below the measured number; measured number inside the range.
By their numbers in this assay, from the lowest: compounds 3, 2, 1 and 4 (each within the scatter of the next, the first and the last beyond it).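

In this assay, within the data shown here, methyl in place of oxolan-3-yl on this oxygen gives a 1.1-fold higher number from compound 1 to compound 4 (0.04 log units; within the scatter) and so provides the first reading at this position, since the earlier steps all changed the group on a carbon with a double bond to nitrogen. In this pair, the oxolan-3-yl ring and its defined stereocentre are lost without a step beyond the scatter. Going by these compounds, whether a longer chain such as butyl or a chain carrying an amine would read the same on this oxygen stays open. No measurement shown gives a reason for this result.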